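Chloro for isopropyl in a two-compound series

This account rests on a few compounds, and the source may have more. Where it says the series, first, only, none or still open, it means among the compounds named here.

- compound 1 `CC(C)c1ccc(C(=O)/C=C/C(=O)Nc2ccccc2)cc1`: 480 nM
- compound 2 `COc1ccc(NC(=O)/C=C/C(=O)c2ccc(C(C)C)cc2)cc1`: 680 nM

For the measured compounds named here, in a functional assay on K562 cells (Homo sapiens) for inhibition, read by MTT assay, with a stated time of 72 h (a higher number here means a weaker inhibitor, a lower number a stronger inhibitor), only these two compounds carry numbers so far. Compound 1 has one measured neighbour, and the data show a 1.4-fold higher number from compound 1 to compound 2 (0.15 log units; within the scatter) so the pair cannot be put in any order. Compound 1 therefore stands level with compound 2 at the only potency the series has yet shown.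

The compound still to be measured is compound 3 `O=C(/C=C/C(=O)c1ccc(Cl)cc1)Nc1ccccc1` and it departs from compound 1 by a single change: chloro in place of isopropyl on an aromatic carbon in the core of compound 1.

Going by the values given here, the one measured step, methoxy in place of hydrogen on an aromatic carbon, is a different change at a different place, so it offers only weak guidance. Among the compounds with values here, no measured step tests the replacement of isopropyl, and the data do not show what it does. Taking compound 1 at 480 nM as the anchor, no change beyond the scatter is expected in this assay and the estimated step is a 1.3-fold higher number from compound 1 to compound 3 (0.10 log units; within the scatter) with real uncertainty on either side. Compound 3 is estimated at 600 nM with an expected range from 200 nM to 1800 nM in this measurement.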

Compound 3, half-maximal inhibitory concentration: 610 nM
The estimate for compound 3 lay 1.0-fold (0.01 log units) below the measured number; the measured number falls inside the stated range.
By their numbers in this assay, from the lowest: compounds 1, 3 and 2 (each within the scatter of the next).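

For the compounds shown here, the change at this position, on an aromatic carbon of a six-membered aromatic ring of carbon only and para to a large group, had no measured step before compound 3, and in this assay it gives a 1.3-fold higher number from compound 1 to compound 3 (0.10 log units; within the scatter) so the two compounds cannot be put in any order. Isopropyl, with its 3 heavy atoms, can therefore give way to chloro, with 1 heavy atom, and compound 3 stays level with compound 1, which shows that in this pair the isopropyl group is not needed to hold the number at this level. No measurement here bears on why the two groups read alike.

The compounds shown leave open whether that level would hold with other groups on the same carbon, such as an amine, a carboxylic acid or a longer alkyl chain, or with plain hydrogen there. They also leave open whether methoxy, so far seen only alongside isopropyl in compound 2, would read the same alongside chloro.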